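This account rests on a few compounds, and the source may have more. Where it says the series, first, only, none or still open, it means among the compounds named here.

Values in a functional assay on U-251 cells (Homo sapiens) for antiproliferative activity, read by MTT assay, with a stated time of 48 h; on this read-out lower numbers stand for stronger inhibition and higher numbers for weaker inhibition:

Compound 1 `COc1cccc(-c2nc3cccc(-c4cc(OC)c(OC)c(OC)c4)c3o2)c1`: > 25000 nM, a limit of the assay and not a number
Compound 2 `COc1ccc(-c2nc3cccc(-c4cc(OC)c(OC)c(OC)c4)c3o2)cc1F`: 1700 nM
Compound 3 `COc1cc(-c2cccc3nc(-c4cccc(N)c4)oc23)cc(OC)c1OC`: 2200 nM

Compound 3, at 2200 nM, cannot be told apart from its nearest neighbour, as a 1.3-fold higher number from compound 2 to compound 3 (0.11 log units; within the scatter) shows. In compound 4 `COc1cc(-c2cccc3nc(-c4cccs4)oc23)cc(OC)c1OC` the shared core stays, with thiophen-2-yl in place of 3-aminophenyl on an aromatic carbon.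

All three measured steps change the group at this same place, so they are the ones that bear on the new change. Two are large, an at least 14-fold lower number from compound 1 to compound 2 (1.16 log units; beyond the scatter) and an at least 11-fold lower number from compound 1 to compound 3 (1.05 log units; beyond the scatter), so the choice of group here can matter a great deal. The third, a 1.3-fold higher number from compound 2 to compound 3 (0.11 log units; within the scatter), is small, so quite different groups can also give similar numbers. Going by the values given here, no measured compound carries thiophen-2-yl, which leaves the direction uncertain.

A modest move towards weaker inhibition in this assay is expected, a 2.3-fold higher number from compound 3 to compound 4 (0.36 log units; beyond the scatter). The wide range reflects the large step seen for compound 1 in an at least 11-fold lower number from compound 1 to compound 3 (1.05 log units; beyond the scatter). For compound 4 the estimated value is 5000 nM, with an expected range of 1200 nM to 25000 nM.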

Compound 4, half-maximal inhibitory concentration: 3000 nM
For compound 4 the middle estimate is 1.7-fold (0.22 log units) above the measured one; the measured number falls inside the stated range.
By their numbers in this assay, from the lowest: compounds 2, 3 and 4 (each within the scatter of the next). At a limit, above all of these: compound 1.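

Swapping 3-aminophenyl for thiophen-2-yl removes the hydrogen-bond donor and replaces the six-membered carbon ring with a five-membered aromatic ring holding sulfur, yet the change gives a 1.4-fold higher number from compound 3 to compound 4 (0.13 log units; within the scatter), and the comparison with the fluorinated compound gives a 1.8-fold higher number from compound 2 to compound 4 (0.25 log units; within the scatter). This position therefore tolerates a five-membered ring as well as the two substituted phenyl groups of compounds 2 and 3, and among the four compounds only compound 1 stands apart, as an at least 8.3-fold lower number from compound 1 to compound 4 (0.92 log units; beyond the scatter) shows. The value of compound 1 is a limit of the assay and not a number: the limit of > 25000 nM in this assay, at which 1 of the 4 values shown sits.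

From the compounds shown here alone, it remains open whether the sulfur itself matters, which furan-2-yl, with oxygen in its place, would help to show. Also open, going by these compounds, is what separates 3-methoxyphenyl from the other groups, a question 3-hydroxyphenyl could narrow.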